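Side-chain variation on the shared core: outlook for compound 3

The source may hold more compounds than are shown below. What is called first, only, known or untested is meant among the compounds shown, and "the series" means these compounds.

Measured so far:
compound 1 `C[C@H](O)Cc1cc(-c2ccnc3[nH]nc(C(F)(F)F)c23)cc(C2(C#N)CC2)c1` gives 51 nM
compound 2 `N#CC1(c2cc(CC(O)C3CC3)cc(-c3ccnc4[nH]nc(C(F)(F)F)c34)c2)CC1` gives 30 nM

In an assay on isolated protein for inhibition of protein kinase C epsilon type (Homo sapiens), read by coupled enzyme assay (a higher number here means a weaker inhibitor, a lower number a stronger inhibitor), compound 1 gives 51 nM. Where compound 1 carries 1-hydroxyethyl on the saturated chain carbon bound to an aromatic carbon, compound 2 carries cyclopropyl(hydroxy)methyl, and compound 2 gives 30 nM. Going by the values given here, the only step available, a 1.7-fold lower number from compound 1 to compound 2 (0.23 log units; within the scatter), leaves the two values within the scatter of one another, so compound 2 stands level with compound 1 rather than apart from it.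

Compound 3 `COCC(O)Cc1cc(-c2ccnc3[nH]nc(C(F)(F)F)c23)cc(C2(C#N)CC2)c1` continues the variation at the same side chain: methoxymethyl in place of cyclopropyl on a saturated chain carbon bound to an oxygen on a saturated carbon and a saturated chain carbon. Among the compounds with values here, the one measured step that bears on this position, a 1.7-fold lower number from compound 1 to compound 2 (0.23 log units; within the scatter), was within the scatter even though it exchanged a methyl for a three-membered ring, and no other step is available. On that basis no shift beyond the scatter is expected from compound 2 to compound 3, which is estimated as a 1.5-fold higher number from compound 2 to compound 3 (0.18 log units; within the scatter). Compound 3 is therefore estimated at 45 nM in this assay, with a range from 15 nM to 130 nM.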

Compound 3, inhibition constant: 77 nM
For compound 3 the middle estimate is 1.7-fold (0.23 log units) below the measured one; measured number inside the range.
By their numbers in this assay, from the lowest: compounds 2, 1 and 3 (each within the scatter of the next, the first and the last beyond it).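

In this assay this side chain now shows a step beyond the scatter, though a modest one: a 2.6-fold higher number from compound 2 to compound 3 (0.41 log units; beyond the scatter) when methoxymethyl replaces cyclopropyl on the carbon next to the hydroxyl-bearing carbon's chain.

Correction to wording above, final notes follow.

In this assay this side chain now shows a step beyond the scatter, though a modest one, with a 2.6-fold higher number from compound 2 to compound 3 (0.41 log units; beyond the scatter) as methoxymethyl replaces cyclopropyl, so the choice of group at this place can separate two compounds where the earlier pair stayed level. The same side chain set against the smaller one does not separate, with a 1.5-fold higher number from compound 1 to compound 3 (0.18 log units; within the scatter) on going to 1-hydroxy-2-methoxyethyl from 1-hydroxyethyl, and so only the two ends of the series, compound 2 and compound 3, stand apart while compound 1 lies within the scatter of both. Nothing available here accounts for the gap between cyclopropyl and methoxymethyl.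

The compounds shown leave open whether that gap follows the loss of the ring or the entry of the ether oxygen, which an all-carbon open chain such as isopropyl or an oxygen-containing ring such as oxetanyl on the same carbon would help to separate. Also open, going by these compounds, is how this place responds to an amine such as dimethylaminomethyl, to a carboxylic acid, or to a longer chain such as 2-methoxyethyl.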